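Methoxy for chloro on the compound 2 scaffold

The source may hold more compounds than are shown below. What is called first, only, known or untested is meant among the compounds shown, and "the series" means these compounds.

Within the data shown here, in a functional assay on HCT-116 cells (Homo sapiens) for inhibition, read by colorimetric assay, with a stated time of 3 days (a lower number here means a stronger inhibitor, a higher number a weaker inhibitor), compound 2 (`O=C(CCCCCCNC(=O)C(O)(O)C(F)(F)F)Nc1nc2ccc(Cl)cc2s1`) gives 11000 nM as the only value that is an actual number. Compound 1 (`CC(=O)C(=O)NCCCCCCC(=O)Nc1ccccc1`) reads > 100000 nM as a limit of the assay. Compound 3 (`O=C(CCCCCNC(=O)c1ccc[nH]1)Nc1ccccc1`) reads > 100000 nM as a limit as well. Compound 4 (`COc1ccc2nc(NC(=O)CCCCCCNC(=O)C(O)(O)C(F)(F)F)sc2c1`) carries methoxy in place of chloro on an aromatic carbon and otherwise matches compound 2. Among the measured compounds shown here, no measured pair shows this change. No step beyond the scatter is expected in this assay in either direction. The estimated step is a 1.2-fold higher number from compound 2 to compound 4 (0.07 log units; within the scatter) on this basis. Compound 4 is estimated at 13000 nM with an expected range from 5000 nM to 35000 nM for the measurement.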

Compound 4, half-maximal inhibitory concentration: 7560 nM
Beside the measured number, compound 4's estimate is 1.7-fold (0.24 log units) above it; low and high end bracket the measured number.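

In this assay, methoxy in place of chloro on this aromatic carbon gives a 1.5-fold lower number from compound 2 to compound 4 (0.16 log units; within the scatter), so the position takes two heavy atoms for one, and a hydrogen-bond acceptor, without a step beyond the scatter. This is the only pair in the series that differs in one place and has an actual number at both ends, which the earlier compounds alone could not provide: the limit of > 100000 nM in this assay, at which 2 of the 4 values shown sit.

As far as these compounds go, whether an amine or a carboxylic acid on the same aromatic carbon would also stay within the scatter remains open. From the compounds shown here alone, the response to a longer chain on the shared core also remains open.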